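The source may hold more compounds than are shown below. What is called first, only, known or untested is meant among the compounds shown, and "the series" means these compounds.

Of the compounds shown here, two of one shared core have been measured in a functional assay on ACHN cells (Homo sapiens) for inhibition, read by sulforhodamine B assay, with a stated time of 48 h, tested at 10 uM; on this read-out lower numbers stand for a stronger effect and higher numbers for a weaker effect at the one concentration tested. Compound 1 `COc1cc(Cl)cc(-c2nn(-c3cccc(NC(=O)c4cc(C(F)(F)F)cc(C(F)(F)F)c4)c3)cc2-c2ccncc2)c1` gives 58.2%. Compound 2 `COc1cc(Cl)cc(-c2nn(-c3cccc(NC(=O)c4ccc(Cl)c(Cl)c4)c3)cc2-c2ccncc2)c1` gives 63.9%. On the numbers shown, compound 2 stands at the top of the two, but its only neighbour, compound 1, sits a short distance below it, a gap that falls within the usual scatter of this kind of measurement, so the two compounds cannot be told apart on this read-out. Among the measured compounds shown here, no pair of measured compounds differs in just one place, so no measured step is available to guide expectations.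

Compound 3 `COc1cc(Cl)cc(-c2nn(-c3cccc(NC(=O)Nc4ccc(Cl)c(Cl)c4)c3)cc2-c2ccncc2)c1` differs from compound 2 in a single place: (3,4-dichlorophenyl)amino in place of 3,4-dichlorophenyl on a carbonyl carbon. Cut one bond further out, the same change reads as (3,4-dichlorophenyl)carbonyl becoming (3,4-dichlorophenyl)carbamoyl. For the measured compounds named here, with no measured step of this kind to draw on, the step of a number 1.9 percentage points lower from compound 2 to compound 3 (within the scatter) in this assay is expected to stay within the scatter, in no firm direction. Compound 3 is therefore estimated to give 62%, with a likely range from 42% to 82%.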

Compound 3, a percentage reported as activity, at one concentration (the size of the read-out at that concentration, not a potency): 9.65%
Compound 3: the middle estimate sits 52.4 percentage points above what was measured; measured number below the stated range.
By their numbers in this assay, from the lowest: compound 3; then compounds 1 and 2 (each within the scatter of the next).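

In this assay, the change from 3,4-dichlorophenyl to (3,4-dichlorophenyl)amino on the carbonyl carbon gives a number 54.3 percentage points lower from compound 2 to compound 3 (beyond the scatter) and so a much stronger effect at the one concentration tested. Among the compounds shown here, this shows that the link between the carbonyl carbon and the dichlorinated ring is a sensitive place: one added nitrogen, counted with one more hydrogen-bond donor, is enough to move the read-out far beyond the usual scatter, something the earlier compounds, with no measured step between them, could not show. The compounds shown offer no measurement that explains why this step is so large.

Going by these compounds, it remains open whether the same swap would work with the two trifluoromethyl groups of compound 1 on the ring, or whether the step belongs to the 3,4-dichlorophenyl group alone. It is also open whether the nitrogen itself is what counts, which a methylene group or an oxygen atom in the same place would test, and a single concentration gives no potency for any of these compounds.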